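The source may report more compounds than this note shows. Statements on the series, on what has been measured and on what is new or still open speak of the compounds shown alone.

Going by the values given here, compound 2 `COc1ccn2c(Nc3cccc(F)c3)c(-c3cscn3)nc2c1` has the highest of the two numbers measured so far in an ADME assay on THP-1 cells (Homo sapiens) for cytotoxicity (on this read-out lower numbers stand for higher toxicity in this test and higher numbers for lower toxicity in this test), where compound 2 gives 40600 nM. Its nearest neighbour is compound 1 `COc1ccn2c(Nc3cccc(F)c3)c(-c3cn(C)cn3)nc2c1`, which in this assay gives 40000 nM; the step of a 1.0-fold higher number from compound 1 to compound 2 (0.01 log units; within the scatter) is within the scatter, so the two compounds cannot be told apart on this read-out. Compound 3 `COc1ccn2c(Nc3cccc(F)c3)c(-c3ccn(C)n3)nc2c1` differs from compound 2 by 1-methyl-1H-pyrazol-3-yl in place of 1,3-thiazol-4-yl on an aromatic carbon, placed on the carbon of the shared core that is next to the ring nitrogen and next to the ring atom that bears the (3-fluorophenyl)amino group. Among the compounds with values here, the only step that bears on this change is the exchange of one five-membered heteroaryl for another from compound 1 to compound 2, which stayed within the scatter. A comparable swap is therefore expected to leave this assay essentially unchanged, with a step of a 1.0-fold lower number from compound 2 to compound 3 (0.01 log units; within the scatter) estimated for compound 3. Compound 3 is expected to give about 40000 nM, within 20000 nM to 80000 nM.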

Compound 3, half-maximal cytotoxic concentration: > 50000 nM
Compound 3: a limit, no number (the forecaster's own chance of this, stated with the estimate: 20%); middle value at least 1.2-fold (0.09 log units) from the limit.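

In this assay compound 3 gives a limit of the assay and not a number: the limit of > 50000 nM in this assay, at which 1 of the 3 values shown sits.

Read against that limit, the change of 1,3-thiazol-4-yl to 1-methyl-1H-pyrazol-3-yl gives an at least 1.2-fold higher number from compound 2 to compound 3 (0.09 log units; that floor lies within the scatter), and the change of 1-methyl-1H-imidazol-4-yl to the same group gives an at least 1.2-fold higher number from compound 1 to compound 3 (0.09 log units; that floor lies within the scatter). Going by these compounds alone, both floors lie within the scatter, so what is new is only that a third five-membered aromatic ring with 2 hetero atoms on this aromatic carbon brings no step down on this read-out, while the true size of the steps stays unknown.

The compounds shown leave open how far compound 3 really stands from compound 1 and compound 2. They also leave open whether a group of another kind on this carbon, such as an amine, a carboxylic acid or a longer alkyl chain, would lower the number.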